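The source may hold more compounds than are shown below. What is called first, only, known or untested is meant among the compounds shown, and "the series" means these compounds.

Measured compounds:
Compound 2 `COc1ccccc1C(=O)NC(=S)NNc1ncnc2ccccc12` gives 15700 nM in a functional assay on CNE-2 cells (Homo sapiens) for cytotoxicity, read by MTT assay, with a stated time of 72 h; on this read-out lower numbers stand for stronger inhibition and higher numbers for weaker inhibition.
Compound 1 `COc1cc2ncnc(NNC(=S)NC(=O)c3ccc(C(F)(F)F)cc3)c2cc1OC` gives 16500 nM in this assay.
Compound 3 `COc1cc2ncnc(NNC(=S)NC(=O)c3ccc(C)cc3)c2cc1OC` gives 33300 nM in this assay.

Of the three numbers, compound 2 has the lowest, but compound 1 lies within the scatter of it, so the two cannot be told apart; only compound 3 stands apart, with a higher number beyond the scatter. The unmeasured compound 4 `O=C(NC(=S)NNc1ncnc2ccccc12)c1ccccc1F` is derived from compound 2 by one change: fluoro in place of methoxy on an aromatic carbon. Going by the values given here, the only step measured so far, a 2.0-fold higher number from compound 1 to compound 3 (0.30 log units; within the scatter), concerns a different change, methyl in place of trifluoromethyl, on the core of compound 1, and it stayed within the scatter. Among the compounds with values here, no measured step bears on fluoro in place of methoxy, so nothing in the data points to a shift in either direction beyond the scatter. Compound 4 is therefore expected to land close to compound 2, with a 1.0-fold higher number from compound 2 to compound 4 (0.01 log units; within the scatter) as the estimated step, that is about 16000 nM in this assay, within an expected range from 6000 nM to 45000 nM.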

Compound 4, half-maximal inhibitory concentration: 4610 nM
Compound 4: middle estimate off by 3.5-fold (0.54 log units), on the high side; measured number below the stated range.
By their numbers in this assay, from the lowest: compound 4; then compounds 2, 1 and 3 (each within the scatter of the next, the first and the last beyond it).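

Replacing methoxy with fluoro on the aromatic carbon ortho to a large group gives a 3.4-fold lower number from compound 2 to compound 4 (0.53 log units; beyond the scatter) in this assay. Going by these compounds alone, this is the first single change here to move the number beyond the scatter, whereas the earlier step, a 2.0-fold higher number from compound 1 to compound 3 (0.30 log units; within the scatter), concerned a different group on a different core and stayed within it. The position on this six-membered aromatic ring is therefore sensitive to what it carries, although nothing shown accounts for the shift.

As far as these compounds go, it remains open whether the lower number reflects the arrival of fluoro or the departure of methoxy, and what chloro, a hydroxyl or an amine would give at this place. Also open, from the compounds shown here alone, is whether the same change would give a similar step on the core of compound 1.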